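This account rests on a few compounds, and the source may have more. Where it says the series, first, only, none or still open, it means among the compounds named here.

Of the compounds shown here, two built on a shared core have so far been measured in an assay on CHO cells for displacement of a labelled ligand from adenosine receptor A1 (Homo sapiens); on this read-out lower numbers stand for stronger inhibition and higher numbers for weaker inhibition. Compound 2, `CCCn1c(=O)c2nc(-c3cnn(Cc4cccc(C)c4)c3)[nH]c2n(CCC)c1=O`, stands at the lowest of the two numbers: in this assay compound 2 gives 48 nM. Among the compounds with values here, compound 1, `CC(C)Cn1c(=O)c2nc(-c3cnn(Cc4cccc(F)c4)c3)[nH]c2n(CC(C)C)c1=O`, is the only other measured compound; in this assay compound 1 gives 830 nM, a number that lies beyond the usual scatter from that of compound 2, and no single step between these two is drawn, so their values are stated side by side and nothing more.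

Compound 3, `CCCn1c(=O)c2nc(-c3cnn(Cc4cccc(Cl)c4)c3)[nH]c2n(CCC)c1=O`, has not yet been measured. It differs from compound 2 in one place only: chloro in place of methyl on an aromatic carbon. Within the data shown here, no pair of measured compounds shows this same change, so the size of its step cannot be read from the data. Compound 3 is expected to remain close to compound 2, with an estimated step of a 1.3-fold higher number from compound 2 to compound 3 (0.10 log units; within the scatter) that need not go beyond the scatter in either direction. In this assay compound 3 is therefore estimated at 60 nM, with an expected range from 20 nM to 200 nM.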

Compound 3, inhibition constant: 31 nM
Compound 3: the middle estimate sits 1.9-fold (0.29 log units) above what was measured; measured number inside the range.
By their numbers in this assay, from the lowest: compounds 3 and 2 (each within the scatter of the next); then compound 1.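

In this assay, chloro in place of methyl on an aromatic carbon, meta to a large group, amounts to a 1.5-fold lower number from compound 2 to compound 3 (0.19 log units; within the scatter), so on this read-out the 3-chlorobenzyl and 3-methylbenzyl groups cannot be told apart. Within the data shown here, this is the first step that can be read between measured compounds differing in one place, and it shows that, for this pair on the shared core with its two propyl chains, one single-atom substituent can stand in for the other without a change beyond the usual scatter. No measurement on hand bears on why the two groups give such similar numbers.

Compound 1 carries fluoro on the same ring but also differs from compound 2 in its chains, so neither the effect of fluoro at this place nor that of the chains can be read from it. Still open, as far as these compounds go, is whether this place would accept a larger or very different group, such as methoxy, trifluoromethyl, an amine or a carboxylic acid, and whether chloro and methyl would stay this close on a core with other chains.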